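Lengthening the Chain on a Kinase Inhibitor's Carbonyl-Bound Oxygen

A few compounds are considered here, and "the series" means these few. Any claim that something is new, unique, unknown or untested is made for them only; others in the source may bear on it.

Compound 1 `COC(=O)c1cccc(-c2cc(C(=O)Nc3ccncc3)ccc2CN)c1` is one of three related compounds tested in an assay on isolated protein for inhibition of Rho-associated protein kinase 2 (Homo sapiens), read by radiometric assay (on this read-out lower numbers stand for stronger inhibition and higher numbers for weaker inhibition), where compound 1 gives 2.9 nM. Compound 3 `NCc1ccc(C(=O)Nc2ccncc2F)cc1-c1cccc(C(=O)OCC2CCCO2)c1` gives 2.5 nM in this assay, and compound 2 `NCc1ccc(C(=O)Nc2ccncc2F)cc1-c1cccc(C(=O)O)c1` gives 55 nM. Compound 1 therefore stands second of the three numbers, close to compound 3 and far from compound 2.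

Compound 4 `CCCOC(=O)c1cccc(-c2cc(C(=O)Nc3ccncc3)ccc2CN)c1` differs from compound 1 in one place: ethyl in place of hydrogen on a saturated chain carbon bound to an oxygen next to a carbonyl group. Put another way, the methoxycarbonyl group becomes a propoxycarbonyl group.

Within the data shown here, the only measured step touching this part of the molecule is a 22-fold lower number from compound 2 to compound 3 (1.34 log units; beyond the scatter), which replaced a hydrogen with a (oxolan-2-yl)methyl group on the oxygen next to the carbonyl. That tells how much a group on that oxygen matters compared with none at all, not how much the size of the group matters. Compounds 1 and 3 carry groups of very different size on that oxygen, yet their numbers sit within the scatter of each other. Extending methyl to propyl is therefore expected to produce little change, and the expected step is a 1.1-fold higher number from compound 1 to compound 4 (0.04 log units; within the scatter). The estimate for compound 4 in this assay is 3.2 nM, within a range from 1.2 nM to 9 nM.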

Compound 4, half-maximal inhibitory concentration: 1.4 nM
Estimate against measurement, compound 4: 2.3-fold (0.36 log units) above, and the stated range covers the measured number.
By their numbers in this assay, from the lowest: compounds 4, 3 and 1 (each within the scatter of the next, the first and the last beyond it); then compound 2.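

Extending methyl to propyl on this saturated chain carbon gives a 2.1-fold lower number from compound 1 to compound 4 (0.32 log units; beyond the scatter) in this assay, a modest step but one that lies beyond the usual scatter. Among these compounds, the only earlier step at this place set a group against a bare hydrogen, whereas this pair shows that the length of the chain on the oxygen can itself move the number, here towards stronger inhibition. Nothing available explains why the longer chain gives the lower number.

The compounds shown leave open whether a still longer chain, such as butyl or hexyl, would continue this direction or reverse it. They also leave open how a branched chain such as isopropyl, or an amide in place of the ester oxygen, would read at this position.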